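Replacing the trihydroxyphenyl group of compound 2

This account rests on a few compounds, and the source may have more. Where it says the series, first, only, none or still open, it means among the compounds named here.

Measured in a functional assay on DU-145 cells (Homo sapiens) for inhibition, read by trypan blue exclusion, with a stated time of 96 h; a lower number here means a stronger inhibitor of growth, a higher number a weaker inhibitor of growth:
- compound 1 `COc1ccc(/C=C(/Sc2ccc(C)cc2)C(=O)c2ccc(Br)cc2)cc1`: 50000 nM
- compound 2 `Cc1ccc(S/C(=C/c2c(O)cc(O)cc2O)C(=O)c2ccc(Br)cc2)cc1`: > 100000 nM (a limit of the assay)

Compound 2 stands at > 100000 nM, which is a limit of the assay and not a number. Compound 3 `CC(=O)c1ccc(/C=C(/Sc2ccc(C)cc2)C(=O)c2ccc(Br)cc2)cc1` carries 4-acetylphenyl in place of 2,4,6-trihydroxyphenyl (4-acetylphenyl in place of 2,4,6-trihydroxyphenyl on a double-bonded chain carbon bound to a double-bonded chain carbon). Within the data shown here, one measured step bears on this place: an at least 2.0-fold higher number from compound 1 to compound 2 (0.30 log units; that floor lies within the scatter). Its floor lies within the scatter, so it offers only weak guidance. Among the measured compounds shown here, compound 1, with 4-methoxyphenyl at that place, gives 50000 nM, the only true number available. The expected step is an at least 2.5-fold lower number from compound 2 to compound 3 (0.39 log units; beyond the scatter), toward a lower number in this assay. For compound 3 the estimate is 40000 nM, with an expected range of 12000 nM to 100000 nM.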

Compound 3, concentration for 50% growth inhibition: 50000 nM
Beside the measured number, compound 3's estimate is 1.3-fold (0.10 log units) below it, and the stated range covers the measured number.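

In this assay the change from methoxy to acetyl on an aromatic carbon gives no change at the digits printed from compound 1 to compound 3 (within the scatter) so this position does not separate these two groups. Putting 4-acetylphenyl in place of 2,4,6-trihydroxyphenyl gives an at least 2.0-fold lower number from compound 2 to compound 3 (0.30 log units; that floor lies within the scatter) and that step has only a floor. Compound 2 at > 100000 nM is a limit of the assay and not a number.

From the compounds shown here alone, what an amine or a carboxylic acid would do on this aromatic ring remains open. So does whether any group at this place gives a clearly lower number than compound 1.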